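Isopropylsulfonyl for propylcarbonyl on compound 2

The source may hold more compounds than are shown below. What is called first, only, known or untested is meant among the compounds shown, and "the series" means these compounds.

In an ADME assay on Vero cells (Chlorocebus sabaeus) for cytotoxicity, read by MTT assay, with a stated time of 48 h (a higher number here means a weaker inhibitor, a lower number a stronger inhibitor), compound 1 (`CC(C)C(=O)OC1CCC(CN2CCN(c3cc(=O)c4cc(C(F)(F)F)cc([N+](=O)[O-])c4s3)CC2)CC1`) gives > 64 ug/mL which is a limit of the assay and not a number. Compound 2 (`CCCC(=O)OC1CCC(CN2CCN(c3cc(=O)c4cc(C(F)(F)F)cc([N+](=O)[O-])c4s3)CC2)CC1`) gives > 64 ug/mL and this too is only a limit. Compound 2 therefore has no numerical position, and the limit of > 64 ug/mL in this assay, at which 2 of the 2 values shown sit, is all that the measurements offer.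

Compound 3 (`CC(C)S(=O)(=O)OC1CCC(CN2CCN(c3cc(=O)c4cc(C(F)(F)F)cc([N+](=O)[O-])c4s3)CC2)CC1`) has isopropylsulfonyl in place of propylcarbonyl on an oxygen on a saturated carbon, a change counted as isopropylsulfonyl in place of propylcarbonyl on an oxygen on a saturated carbon in full. Within the data shown here, the only measured step is a step that the two limits leave unreadable from compound 1 to compound 2 and it provides no size to carry over. No step beyond the scatter and no direction can be foreseen in this assay from it. The expected step is a step that the limit leaves unreadable from compound 2 to compound 3 and no more is claimed. For compound 3 the estimate is 80 ug/mL with an expected range of 40 ug/mL to 160 ug/mL and a further limit is the likeliest report.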

Compound 3, half-maximal inhibitory concentration: > 64 ug/mL
Compound 3 was reported as a limit; the forecaster's own chance of this, stated with the estimate: 80%; the middle value is on the limit's open side.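

Compound 3, like compound 1 and compound 2, is reported only as a limit of the assay, so no step among these compounds can be read: the limit of > 64 ug/mL in this assay, at which 3 of the 3 values shown sit.

The compounds shown leave open what number any of the three would give in this assay, and whether isopropylsulfonyl in place of propylcarbonyl changes it at all.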